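The source may hold more compounds than are shown below. What is called first, only, known or untested is meant among the compounds shown, and "the series" means these compounds.

In an ADME assay on CCRF-HSB-2 cells (Homo sapiens) for cytotoxicity, with a stated time of 7 days (on this read-out lower numbers stand for higher toxicity in this test and higher numbers for lower toxicity in this test), compound 1 (`CN(C)c1nc(N)nc2c1ncn2/C=C1/CC1(CO)CO`) gives > 20000 nM as a limit and not a number. Compound 2 (`CSc1nc(N)nc2c1ncn2/C=C1/CC1(CO)CO`) gives > 100000 nM and stands on a limit only. Among the measured compounds shown here, the one measured step is a step that the two limits leave unreadable from compound 1 to compound 2 and offers no size to carry forward. The change to compound 3 (`CCCOc1nc(N)nc2c1ncn2/C=C1/CC1(CO)CO`) is propoxy in place of methylsulfanyl on an aromatic carbon, counted as propoxy in place of methylsulfanyl on an aromatic carbon on the shared core. With no readable step behind it, this assay gives no ground for a shift, so the expected step is a number no higher from compound 2 to compound 3 (the limit leaves the size open) and nothing beyond the scatter is expected. For compound 3 the estimate is 100000 nM with an expected range of 25000 nM to 200000 nM in this test.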

Compound 3, half-maximal cytotoxic concentration: > 20000 nM
Compound 3: no number, only a limit (the forecaster's own chance of this, stated with the estimate: 80%); the middle value is on the limit's open side.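

In this assay, among the compounds shown here, compound 1, compound 2 and compound 3 all stand on limits and not numbers, so no step among them can be read. The compounds shown leave open whether exchanging dimethylamino, methylsulfanyl and propoxy changes the read-out at all.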